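A few compounds are considered here, and "the series" means these few. Any claim that something is new, unique, unknown or untested is made for them only; others in the source may bear on it.

In a functional assay on HepG2 cells (Homo sapiens) for inhibition, read by MTT assay, with a stated time of 48 h, tested at 10 uM (on this read-out higher numbers stand for more inhibition of growth at the one concentration tested and lower numbers for less inhibition of growth), two compounds have been measured:

Compound 1, `COc1ccc(C(=O)/C=C/c2ccc(OCc3cn(Cc4cccc(Br)c4)nn3)cc2)cc1`: 27%
Compound 2, `COc1ccc(C(=O)/C=C/c2ccc(OCc3cn(Cc4cccc(F)c4)nn3)cc2)cc1`: 22%

Compound 1 is the reference point here. Within the data shown here, the only other measured compound, compound 2, differs from it by fluoro in place of bromo on an aromatic carbon, and the step of a number 5 percentage points lower from compound 1 to compound 2 (within the scatter) lies within the scatter, so the two numbers cannot be told apart.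

Compound 3 is `O=C(/C=C/c1ccc(OCc2cn(Cc3cccc(Br)c3)nn2)cc1)c1ccc([N+](=O)[O-])cc1`. Relative to compound 1 the change is nitro in place of methoxy on an aromatic carbon; cut one bond further out it reads (4-methoxyphenyl)carbonyl to (4-nitrophenyl)carbonyl. Among the measured compounds shown here, no measured step touches this part of the molecule. For the measured compounds named here, the single step on record, a number 5 percentage points lower from compound 1 to compound 2 (within the scatter), sits on the benzyl ring at the other end of the shared core and was itself within the scatter. It therefore says nothing about how the carbonyl-side ring responds, and the expectation must stay close to compound 1, with a wide range to reflect the lack of a comparable step.

Compound 3 is accordingly expected to give about 30%, within 12% to 50%, an estimated step of a number 3 percentage points higher from compound 1 to compound 3 (within the scatter) that is not expected to exceed the scatter.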

Compound 3, percent growth inhibition at one concentration: 13%
Estimate against measurement, compound 3: 17 percentage points above, and the stated range covers the measured number.
By their numbers in this assay, from the lowest: compounds 3, 2 and 1 (each within the scatter of the next, the first and the last beyond it).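

In this assay, the 4-methoxyphenyl group on the carbonyl proves sensitive to change: nitro in place of methoxy gives a number 14 percentage points lower from compound 1 to compound 3 (beyond the scatter). This is a modest change, but unlike fluoro in place of bromo elsewhere in the molecule, which gives a number 5 percentage points lower from compound 1 to compound 2 (within the scatter), it is large enough to be told apart from ordinary assay variation. No measurement shown here accounts for the loss of growth inhibition, so the result establishes only its direction and size for this one pair.

With only methoxy and nitro represented at this position, it remains unclear whether the lower number reflects losing methoxy or gaining nitro, and an amine, a hydroxy group or a longer ether such as ethoxy in the same place would help separate those two possibilities. It also remains open whether the same replacement would have a similar effect with fluoro instead of bromo at the other end of the shared core, and how any of these compounds would behave at other concentrations.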